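A few compounds are considered here, and "the series" means these few. Any claim that something is new, unique, unknown or untested is made for them only; others in the source may bear on it.

In a functional assay on SEM cells (Homo sapiens) for cytotoxicity, with a stated time of 72 h (on this read-out lower numbers stand for an effect already at smaller amounts and higher numbers for an effect only at larger amounts of compound), compound 1 `CC(C)=CCC[C@](C)(/C=C/c1ccc(O)cc1)/C=C/c1cccc(Cl)c1` gives only a limit, > 36600 nM, and no number. Compound 2 `C=C[C@@](C)(/C=C/c1ccc(Nc2ccc(OC)cc2)cc1)CCC=C(C)C` likewise gives only a limit in this assay, > 36600 nM. So compound 2 stands at the same limit as the other value shown, (the limit of > 36600 nM in this assay, at which 2 of the 2 values shown sit), and no measured step in the series carries a number. Compound 3 `C=C[C@@](C)(/C=C/c1ccc(Nc2ccc(Cl)c(Cl)c2)cc1)CCC=C(C)C` differs from compound 2 by 3,4-dichlorophenyl in place of 4-methoxyphenyl on a nitrogen on an aromatic ring. Going by the values given here, with no quantified step to draw on, no shift beyond the scatter is expected a step that the limit leaves unreadable from compound 2 to compound 3. For compound 3 in this assay the estimate is 40000 nM, within a range of 15000 nM to 110000 nM, most likely again reported as a limit.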

Compound 3, half-maximal effective concentration: > 36600 nM
Compound 3 gave a limit, no number (the forecaster's own chance of this, stated with the estimate: 70%); the middle value is on the limit's open side.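

In this assay, going by these compounds alone, compound 3 gives only a limit, as does compound 2, and no step between compound 2 and compound 3 can be read. The compounds shown leave open which change on the shared core, if any, would yield a measurable value.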